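The source may hold more compounds than are shown below. What is called first, only, known or untested is meant among the compounds shown, and "the series" means these compounds.

- compound 1 `O=C(NS(=O)(=O)c1ccc(F)cc1)c1ccncc1` with 9200 nM measured
- compound 2 `O=C(NS(=O)(=O)c1ccc(Cl)cc1)c1ccncc1` with 8900 nM measured

In a functional assay on RAW264.7 cells (Mus musculus) for inhibition (a higher number here means a weaker inhibitor, a lower number a stronger inhibitor), compound 2 gives 8900 nM as its result, level with compound 1 at 9200 nM on the same scale. The two numbers cannot be told apart, so neither compound can be ranked above the other.

The next compound is compound 3 `O=C(NS(=O)(=O)c1ccc(Br)cc1)c1ccncc1`, and it differs from compound 2 in one place: bromo in place of chloro on an aromatic carbon describes the swap, bromo in place of chloro on an aromatic carbon.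

Going by the values given here, only one measured step bears on this change. It is the swap of chloro in place of fluoro at that same carbon, a 1.0-fold lower number from compound 1 to compound 2 (0.01 log units; within the scatter) in size, which lies within the scatter. One small step is thin evidence and shows nothing directly about bromo, yet it gives no reason to expect a real shift in this assay here. The expected change is a 1.0-fold lower number from compound 2 to compound 3 (0.02 log units; within the scatter) and so no step beyond the scatter, in either direction. For compound 3 the estimate is 8500 nM as a likely result, with an expected range from 4500 nM up to 16000 nM as its limits.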

Compound 3, half-maximal inhibitory concentration: 5500 nM
Beside the measured number, compound 3's estimate is 1.5-fold (0.19 log units) above it, within the range that was stated.
By their numbers in this assay, from the lowest: compounds 3, 2 and 1 (each within the scatter of the next).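

In this assay, a third halogen on this aromatic carbon, para to a large group, still gives no difference that can be told from the scatter: the swap of bromo for chloro gives a 1.6-fold lower number from compound 2 to compound 3 (0.21 log units; within the scatter), and the swap of bromo for fluoro gives a 1.7-fold lower number from compound 1 to compound 3 (0.22 log units; within the scatter). Both steps are greater in size than the earlier step of a 1.0-fold lower number from compound 1 to compound 2 (0.01 log units; within the scatter), yet neither passes beyond the scatter, so fluoro, chloro and bromo at this position still cannot be placed in any order. Nothing else measured on these compounds speaks to why their numbers fall where they do.

The compounds shown carry only these single halogens at this carbon, so it stays open whether a different kind of group there, such as an amine, a carboxylic acid, a methoxy group or a longer chain, would move the number beyond the scatter. On these data alone, how the number responds to a change elsewhere in the shared core also stays open.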